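The source may hold more compounds than are shown below. What is called first, only, known or untested is meant among the compounds shown, and "the series" means these compounds.

Two compounds here share one core and differ only in the group joined to the carbonyl carbon of the amide. Compound 1 `CCn1c(C(=O)NCCN)ccc1C(CC)(CC)c1ccc(OCCC(O)(CC)CC)c(C)c1` carries a (2-aminoethyl)amino group there; in a functional assay on MCF7 cells (Homo sapiens) for antiproliferative activity, read by MTT assay, with a stated time of 48 h (a lower number here means a stronger inhibitor, a higher number a weaker inhibitor), compound 1 gives 670 nM, the highest of the two numbers recorded so far. Compound 2 `CCn1c(C(=O)N(C)CC(=O)O)ccc1C(CC)(CC)c1ccc(OCCC(O)(CC)CC)c(C)c1` carries a (carboxymethyl)(methyl)amino group in that place, and in this assay compound 2 gives 79 nM; the step of an 8.5-fold lower number from compound 1 to compound 2 (0.93 log units; beyond the scatter) shows that a change at this position can move the number well beyond the scatter. Compound 3 `CCC(C)C(CO)NC(=O)c1ccc(C(CC)(CC)c2ccc(OCCC(O)(CC)CC)c(C)c2)n1CC` has not yet been measured. It differs from compound 1 in one place: 1-(hydroxymethyl)-2-methylbutyl in place of 2-aminoethyl on an amide-type nitrogen. Going by the values given here, the only measured step that touches the same amide-type nitrogen is an 8.5-fold lower number from compound 1 to compound 2 (0.93 log units; beyond the scatter), but that step exchanged the group for a quite different one, so it guides only loosely. A change in the same direction, probably smaller and with wide uncertainty, is expected. Compound 3 is therefore estimated at 250 nM, with a likely range from 60 nM to 1000 nM, corresponding to an expected step of a 2.7-fold lower number from compound 1 to compound 3 (0.43 log units; beyond the scatter).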

Compound 3, half-maximal inhibitory concentration: 29100 nM
Compound 3: middle estimate off by 120-fold (2.07 log units), on the low side, outside the stated range (above it).
By their numbers in this assay, from the lowest: compound 2; then compound 1; then compound 3.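

In this assay, the group on the amide-type nitrogen can push the number up as well as down: the step of a 43-fold higher number from compound 1 to compound 3 (1.64 log units; beyond the scatter) runs opposite to the earlier step and is larger, so this position does not accept every change. Against compound 2, the 1-(hydroxymethyl)-2-methylbutyl group gives the widest gap in this set, a 370-fold higher number from compound 2 to compound 3 (2.57 log units; beyond the scatter), and 2-aminoethyl and the group that replaces it have the same count of hydrogen-bond donors and of acceptors, so those counts alone do not follow the number in compounds 1 and 3. Nothing given here accounts for the large rise in the number on going to this group of 7 heavy atoms from one of 3.

The new group differs from 2-aminoethyl in chain length, branching and its hydroxyl at once, and the compounds shown do not separate these features; a plain unbranched butyl chain or a 2-hydroxyethyl group on this nitrogen would help to do so. As far as these compounds go, it also remains open whether carboxymethyl keeps its low number when the amide nitrogen carries a hydrogen in place of the methyl group.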